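Isopropyl to Pyridin-4-yl on the Ring Amine

A few compounds are considered here, and "the series" means these few. Any claim that something is new, unique, unknown or untested is made for them only; others in the source may bear on it.

Of the compounds shown here, three sharing one core have been tested in an assay on CHO cells for displacement of a labelled ligand from adenosine receptor A1 (Homo sapiens), read by scintillation counting, with a stated time of 120 min, tested at 10 uM; on this read-out higher numbers stand for more inhibition at the one concentration tested (going by the name of the read-out) and lower numbers for less inhibition. Compound 1 `CC(C)N1CCN(Cc2csc(N)c2C(=O)c2ccc(Cl)cc2)CC1` gives 0%, compound 2 `Nc1scc(CN2CCN(c3cccc(Cl)c3Cl)CC2)c1C(=O)c1ccc(Cl)cc1` gives 2% and compound 3 `Nc1scc(CN2CCN(c3cccnc3)CC2)c1C(=O)c1ccc(Cl)cc1` gives 0%. Compound 1 stands at the same figure as compound 3, and every measured number here sits within the scatter of every other. Compound 4 `Nc1scc(CN2CCN(c3ccncc3)CC2)c1C(=O)c1ccc(Cl)cc1` differs from compound 1 in one place: pyridin-4-yl in place of isopropyl on an amine nitrogen in a ring. The relevant precedents are a number 2 percentage points higher from compound 1 to compound 2 (within the scatter) and no change at the digits printed from compound 1 to compound 3 (within the scatter), both within the scatter, as is a number 2 percentage points lower from compound 2 to compound 3 (within the scatter). Putting an aromatic ring in place of the isopropyl has so far moved nothing. No step beyond the scatter is expected for compound 4, so the expected step is a number 1 percentage points higher from compound 1 to compound 4 (within the scatter). Compound 4 is therefore estimated at 1%, in a range from -5% to 8%.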

Compound 4, a percentage reported as inhibition, at one concentration (the size of the read-out at that concentration, not a potency): 1%
Compound 4: middle estimate and measured number agree at the digits printed; the range from low to high includes it.
By their numbers in this assay, from the lowest: compounds 1, 3, 4 and 2 (each within the scatter of the next).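

In this assay, pyridin-4-yl on the amine nitrogen gives a number 1 percentage points higher from compound 1 to compound 4 (within the scatter), so this third aromatic ring also leaves the isopropyl result unchanged. Moving the ring nitrogen gives a number 1 percentage points higher from compound 3 to compound 4 (within the scatter), and replacing the two chlorines and the benzene ring with pyridine gives a number 1 percentage points lower from compound 2 to compound 4 (within the scatter), so neither the place of that nitrogen nor the choice of aromatic ring separates these compounds. Nothing available explains these results.

On these data alone, whether a carboxylic acid or a longer chain ending in an amine on this nitrogen would give a number beyond the scatter remains open.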